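The source may hold more compounds than are shown below. What is called first, only, known or untested is meant among the compounds shown, and "the series" means these compounds.

Measured in a functional assay on NCI-H322M cells (Homo sapiens) for cytotoxicity, read by sulforhodamine B assay, with a stated time of 48 h; a lower number here means that less compound is tolerated, a higher number that more compound is tolerated:
compound 1 `ClCc1ccccc1Cn1cnc2c(Cl)nc(Cl)nc21` gives 5880 nM
compound 2 `ClCc1ccccc1Cn1cnc2c(Cl)ncnc21` gives 43700 nM
compound 3 `ClCc1ccccc1Cn1cnc2ncnc(Cl)c21` gives 40700 nM

Compound 2 and compound 3 have the same atoms joined differently; the difference between the two cores is not broken down here, and their two numbers lie within the scatter of each other. The change chloro in place of hydrogen on an aromatic carbon gave a 7.4-fold lower number from compound 2 to compound 1 (0.87 log units; beyond the scatter), a step beyond the scatter.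

Compound 4 `ClCc1ccccc1Cn1cnc2nc(Cl)nc(Cl)c21` has not been measured. It arises from compound 3 by chloro in place of hydrogen on an aromatic carbon, the same kind of change, with the place described in the same words as before. Compound 4 is expected to show a 6.8-fold lower number from compound 3 to compound 4 (0.83 log units; beyond the scatter) because the same change gave a 7.4-fold lower number from compound 2 to compound 1 (0.87 log units; beyond the scatter). Within the data shown here, compound 4 is therefore estimated at about 6000 nM in this assay, plausibly between 2500 nM and 15000 nM, with the range left wide since only one earlier instance of the change is known.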

Compound 4, concentration lethal to 50% of the cells: 39800 nM
Estimate against measurement, compound 4: 6.6-fold (0.82 log units) below, and the stated range ends below it.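

Chloro in place of hydrogen on an aromatic carbon gave a 1.0-fold lower number from compound 3 to compound 4 (0.01 log units; within the scatter), so in this assay the step seen on the core of compound 2 did not carry over to the core of compound 3. The two instances differ: the same change on two cores in this assay, a 7.4-fold lower number (0.87 log units; beyond the scatter) from compound 2 to compound 1 and a 1.0-fold lower number (0.01 log units; within the scatter) from compound 3 to compound 4, 7.3-fold (0.86 log units) apart, beyond the scatter of two such steps. With only two instances, this shows that the size of the step is not transferable between these two cores, but it does not show what in the cores sets them apart or how the change would behave on any further core.

The compounds shown carry only chloro or hydrogen at the changed places, so an amine, a methoxy group or a fluoro group there remains open. Going by these compounds, replacing the chloromethyl group, for example by a hydroxymethyl group, also remains open.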